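Aryl substituent swap on the shared core: acid dissociation notes

A few compounds are considered here, and "the series" means these few. Any claim that something is new, unique, unknown or untested is made for them only; others in the source may bear on it.

Measured so far in a physicochemical assay for acid dissociation:
- compound 1 `CCC(CC)c1ccc2c(NCCCNCc3cc(F)ccc3OC)ccnc2c1`: 9.47
- compound 2 `COc1ccc(F)cc1CNCCCNc1ccnc2cc(Cc3ccc(F)cc3)ccc12`: 9.47

Among the compounds with values here, compound 2 stands level with compound 1 at the digits given; the one measured step, no change at the digits printed from compound 1 to compound 2 (within the scatter), shows no movement beyond the scatter when the aromatic substituent on the shared core is exchanged. The site of that exchange lies remote from the amine centres that carry the ionisable protons, and the measurement did not register the change.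

Compound 3 `COc1ccc(F)cc1CNCCCNc1ccnc2cc(-c3cccc4ccccc34)ccc12` is the next member, and it differs from compound 2 only at that same position: naphthalen-1-yl in place of 4-fluorobenzyl on an aromatic carbon. Within the data shown here, the only measured step that bears on this position, no change at the digits printed from compound 1 to compound 2 (within the scatter), is the relevant precedent, and it was flat. On that basis the step of no change at the digits printed from compound 2 to compound 3 (within the scatter) is expected to stay within the scatter, with no direction to assign. The estimate for compound 3 in this assay is therefore 9.47, expected to fall between 9.15 and 9.8.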

Compound 3, acid dissociation constant: 9.47
Compound 3: middle estimate and measured number agree at the digits printed; the range from low to high includes it.
By their numbers in this assay, from the lowest: compounds 1, 2 and 3 (each within the scatter of the next).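

In this assay, exchanging 4-fluorobenzyl for naphthalen-1-yl gives no change at the digits printed from compound 2 to compound 3 (within the scatter), so the flat reading at this aromatic carbon now extends to a group with two six-membered aromatic rings of carbon only and no fluorine. Set against the pentan-3-yl group, the same naphthalen-1-yl group gives no change at the digits printed from compound 1 to compound 3 (within the scatter), which leaves three different groups at this position, pentan-3-yl, 4-fluorobenzyl and naphthalen-1-yl, all level within the scatter, where the earlier pair offered only two. No supporting data are available to account for this flat reading.

As far as these compounds go, both 4-fluorobenzyl and naphthalen-1-yl carry no hydrogen-bond donors or acceptors and no net charge, so it remains open whether an amine or a carboxylic acid at this aromatic carbon would also leave the reading in this assay unmoved. The compounds shown also leave open whether a change elsewhere on the shared core, rather than at this position, would stay within the scatter.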